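A few compounds are considered here, and "the series" means these few. Any claim that something is new, unique, unknown or untested is made for them only; others in the source may bear on it.

Measured compounds:
- compound 1 `CC(C(=O)NCc1ccc(C(F)(F)F)nc1NCc1cccnc1)c1ccc(NS(C)(=O)=O)c(F)c1`: "not active" (no number reported)
- compound 2 `C[C@H](C(=O)NCc1ccc(C(F)(F)F)nc1N1CCC(c2ccccc2)CC1)c1ccc(NS(C)(=O)=O)c(F)c1`: 17.4 nM
- compound 3 `Cc1ccc(CC2CCN(c3nc(C(F)(F)F)ccc3CNC(=O)C(C)c3ccc(NS(C)(=O)=O)c(F)c3)CC2)cc1`: 17 nM

For the measured compounds named here, in a functional assay on CHO-K1 cells for antagonist activity at transient receptor potential cation channel subfamily V member 1 (Homo sapiens), read by FLIPR (on this read-out lower numbers stand for stronger inhibition and higher numbers for weaker inhibition), compound 1 is reported as "not active" (no number reported), so no number stands for it; it is the only compound here without one. Compound 2 gives 17.4 nM and compound 3 gives 17 nM in this assay, both strong inhibitors whose values sit within the usual scatter of each other, so nothing separates them.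

Compound 4 `CC(C(=O)NCc1ccc(C(F)(F)F)nc1N1CCCCCC1)c1ccc(NS(C)(=O)=O)c(F)c1` is not yet measured. It differs from compound 1 in one place: azepan-1-yl in place of ((pyridin-3-yl)methyl)amino on an aromatic carbon. Compounds 2 and 3 are also changed from compound 1 at that same part of the shared core, and both give strong inhibition, whereas compound 1 with its ((pyridin-3-yl)methyl)amino group gives none. On this basis a large step toward lower numbers in this assay is expected from compound 1 to compound 4, far beyond the scatter, though the azepan-1-yl group is smaller than what compounds 2 and 3 carry, so the expected value is set somewhat above theirs. Compound 4 is expected to give about 60 nM in this assay, with a plausible range from 10 nM to 400 nM.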

Compound 4, half-maximal inhibitory concentration: 25.1 nM
For compound 4 the middle estimate is 2.4-fold (0.38 log units) above the measured one, and the stated range covers the measured number.
By their numbers in this assay, from the lowest: compounds 3, 2 and 4 (each within the scatter of the next).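

For the compounds shown here, compound 1 is reported without a number in this assay, which leaves no step to read between it and compound 4. The compounds shown leave open how far the azepan-1-yl group of compound 4 accounts for its activity, and no measurement here speaks to a cause.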